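The compounds below may be only part of what the source reports. "The series", "measured", "known", "first", "only" and "open" are said of these compounds alone.

Measured so far:
compound 1 `O=C(NCc1ccc(F)cc1)c1ccc(N2CCN(S(=O)(=O)c3cccnc3C3CC3)CC2)nn1`: 0.1 h
compound 2 `Cc1nc(C(F)(F)F)ccc1S(=O)(=O)N1CCN(c2ccc(C(=O)NCc3ccc(F)cc3)nn2)CC1`: 0.383 h

Among the measured compounds shown here, in an ADME assay on microsomes from liver (Mus musculus) for metabolic stability, read by LC-MS, using NADPH, tested at 10 uM (on this read-out lower numbers stand for a shorter-lived compound and higher numbers for a longer-lived compound), compound 2 gives 0.383 h, the higher of the two numbers, and its only neighbour is compound 1 at 0.1 h. For the measured compounds named here, the single measured step, a 3.8-fold higher number from compound 1 to compound 2 (0.58 log units; beyond the scatter), exchanges the whole aryl group on the sulfonyl sulfur, so it bears on the next change only in part. Compound 3 `Cc1ncccc1S(=O)(=O)N1CCN(c2ccc(C(=O)NCc3ccc(F)cc3)nn2)CC1` differs from compound 2 by hydrogen in place of trifluoromethyl on an aromatic carbon. This removes one of the two groups that entered between compound 1 and compound 2, while the methyl stays in place. Going by the values given here, compound 3 is therefore expected to sit somewhat below compound 2, by a step of a 1.9-fold lower number from compound 2 to compound 3 (0.28 log units; within the scatter), though with no measured pair that isolates the trifluoromethyl alone the direction is uncertain. In this assay compound 3 is estimated at 0.2 h, with a range from 0.08 h to 0.5 h.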

Compound 3, half-life: 0.133 h
The estimate for compound 3 lay 1.5-fold (0.18 log units) above the measured number; low and high end bracket the measured number.
By their numbers in this assay, from the lowest: compounds 1 and 3 (each within the scatter of the next); then compound 2.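

In this assay, the trifluoromethyl group next to the ring nitrogen can now be read on its own: hydrogen in its place gives a 2.9-fold lower number from compound 2 to compound 3 (0.46 log units; beyond the scatter), which accounts for the larger part of a 3.8-fold higher number from compound 1 to compound 2 (0.58 log units; beyond the scatter). The other exchange in that earlier step, methyl in place of cyclopropyl, gives a 1.3-fold higher number from compound 1 to compound 3 (0.12 log units; within the scatter), so it shows no difference that can be told from the scatter. Nothing measured here explains why the half-life goes with the trifluoromethyl group.

On these data alone, it remains open whether another group on this carbon, such as chlorine, a nitrile or methoxy, would match trifluoromethyl. As far as these compounds go, it is also open whether trifluoromethyl would have the same effect alongside cyclopropyl in place of the methyl.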